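The source may report more compounds than this note shows. Statements on the series, on what has been measured and on what is new or still open speak of the compounds shown alone.

Working notes on the series. The shared core is constant; the three measured compounds differ only in the aryl group on a nitrogen on an aromatic ring. Compound 1 `CCS(=O)(=O)Nc1cc(-c2ccc3ncnc(Nc4ccc(F)cc4F)c3c2)cnc1OC` gives 2490 nM in a functional assay on SK-HEP1 cells (Homo sapiens) for cytotoxicity, read by sulforhodamine B assay, with a stated time of 72 h; on this read-out lower numbers stand for stronger inhibition and higher numbers for weaker inhibition. Compound 2 `CCS(=O)(=O)Nc1cc(-c2ccc3ncnc(Nc4ccc(OC)c(OC)c4)c3c2)cnc1OC` gives 2840 nM in this assay. Compound 3 `CCS(=O)(=O)Nc1cc(-c2ccc3ncnc(Nc4ccc(F)c(C(=O)OC)c4)c3c2)cnc1OC` gives 5180 nM in this assay, the highest of the three numbers: the step of a 2.1-fold higher number from compound 1 to compound 3 (0.32 log units; beyond the scatter) lies beyond the scatter, whereas a 1.8-fold higher number from compound 2 to compound 3 (0.26 log units; within the scatter) and a 1.1-fold higher number from compound 1 to compound 2 (0.06 log units; within the scatter) stay within it.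

Compound 4 `CCS(=O)(=O)Nc1cc(-c2ccc3ncnc(Nc4ccc(OC)nc4)c3c2)cnc1OC` differs from compound 3 in one place: 6-methoxypyridin-3-yl in place of 4-fluoro-3-(methoxycarbonyl)phenyl on a nitrogen on an aromatic ring. All three measured steps bear on this position, since each exchanges the aryl group on the same nitrogen, and none of them exceeds a modest size. On that basis the step in this assay from compound 3 to compound 4 is expected to be small, a 1.7-fold lower number from compound 3 to compound 4 (0.24 log units; within the scatter), toward a somewhat lower number, given that compound 3 sits at the high end with 5180 nM. Compound 4 is accordingly estimated at 3000 nM in this assay, with a range from 1200 nM to 7500 nM.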

Compound 4, half-maximal inhibitory concentration: 3440 nM
Beside the measured number, compound 4's estimate is 1.1-fold (0.06 log units) below it; the range from low to high includes it.
By their numbers in this assay, from the lowest: compounds 1, 2, 4 and 3 (each within the scatter of the next, the first and the last beyond it).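

In this assay, among the compounds shown here, 6-methoxypyridin-3-yl is the first group here with a hetero atom in its six-membered aromatic ring, and none of its steps against the carbon-only aryl groups lies beyond the scatter (a 1.5-fold lower number from compound 3 to compound 4 (0.18 log units; within the scatter); a 1.2-fold higher number from compound 2 to compound 4 (0.08 log units; within the scatter); a 1.4-fold higher number from compound 1 to compound 4 (0.14 log units; within the scatter)). On a nitrogen on an aromatic ring, this position therefore accepts a ring hetero atom and, against compound 3, a change to a group with fewer heavy atoms without a step that can be told from the scatter. No accompanying data explain this result.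

The compounds shown leave open whether an aryl group carrying an amine or a carboxylic acid would give a step beyond the scatter. They also leave open what a longer chain in place of the aryl group would do to the number.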